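This account rests on a few compounds, and the source may have more. Where it says the series, first, only, none or still open, it means among the compounds named here.

Of the compounds shown here, three have been measured, and they share one core. Compound 1 `COc1ccc(C(=O)c2sc3nc(-c4cccs4)ccc3c2N)c(OC)c1` is a ketone, and in a functional assay on WI-38 VA13 cells (Homo sapiens) for cytotoxicity (a higher number here means that more compound is needed for the effect, a lower number that less compound is needed), compound 1 gives 0.52 ug/mL. Compound 2 `COc1ccc(OC)c(C(=O)c2sc3nc(-c4cccs4)ccc3c2N)c1` is likewise a ketone, and in this assay compound 2 gives 0.079 ug/mL. Compound 3 `CCOC(=O)c1sc2nc(-c3cccs3)ccc2c1N` is instead an ester, and in this assay compound 3 reaches only a limit of the measurement, > 4 ug/mL. Where compound 3 stands is therefore known only as the limit of > 4 ug/mL in this assay, at which 1 of the 3 values shown sits, not as a number.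

Compound 4 `Nc1c(C(=O)c2ccc(F)cc2)sc2nc(-c3cccs3)ccc12` has not yet been measured in this assay. It differs from compound 3 by 4-fluorophenyl in place of ethoxy on a carbonyl carbon, that is, a 4-fluorophenyl in place of ethoxy on a carbonyl carbon, turning the ester into a ketone. Since the two ketones compound 1, with 0.52 ug/mL, and compound 2, with 0.079 ug/mL, both sit well inside the measured range, the step from the ester to a ketone is expected to move the number downward by a large amount, beyond the scatter, as an at least 8.0-fold lower number from compound 3 to compound 4 (0.90 log units; beyond the scatter). Compound 4 is accordingly expected to come out near 0.5 ug/mL, within a range from 0.1 ug/mL to 2.5 ug/mL.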

Compound 4, half-maximal effective concentration: 1.8 ug/mL
Compound 4: middle estimate off by 3.6-fold (0.56 log units), on the low side, and the stated range covers the measured number.
By their numbers in this assay, from the lowest: compound 2; then compound 1; then compound 4. At a limit, above all of these: compound 3.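

Putting 4-fluorophenyl in place of ethoxy on the carbonyl carbon gives an at least 2.2-fold lower number from compound 3 to compound 4 (0.34 log units; beyond the scatter) in this assay. Going by these compounds alone, this is the first step between two measured compounds that differ in one place, and it shows that this single change, from ester to ketone, is enough to bring the number from a limit to a measured value. Compound 3 stands only at a limit, so the step gives a minimum size and not the full one: the limit of > 4 ug/mL in this assay, at which 1 of the 4 values shown sits.

The step exchanges the ethoxy for a whole aromatic ring at once, so the shown compounds do not separate the loss of the ester oxygen from the entry of the ring or its fluorine. A plain phenyl, a phenyl ester, an amide formed with an amine or a carboxylic acid at this carbonyl carbon would each bear on that question.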